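A few compounds are considered here, and "the series" means these few. Any claim that something is new, unique, unknown or untested is made for them only; others in the source may bear on it.

Measured compounds:
compound 1, `O=C(Nc1cc(-c2ccccc2)nn1-c1ccccc1)c1ccccc1` — in an assay on HEK293 cells for displacement of a labelled ligand from metabotropic glutamate receptor 5 (Rattus norvegicus) (a higher number here means a weaker inhibitor, a lower number a stronger inhibitor), compound 1 gives 4180 nM.
compound 2, `O=C(Nc1cc(-c2ccccc2Cl)nn1-c1ccccc1)c1ccccc1` — compound 2 reaches only the limit of > 10000 nM, a boundary of this assay rather than a number.
compound 3, `O=C(Nc1c(-c2ccccc2)cnn1-c1ccccc1)c1ccccc1` — compound 3 gives 1170 nM.

Of the two plain numbers, compound 3 holds the lower one, and the nearest number, that of compound 1, stands higher by a margin beyond the usual scatter. Compound 4, `O=C(Nc1c(-c2ccccc2)cnn1-c1ccccc1)c1ccc([N+](=O)[O-])cc1`, is compound 3 with a single change: nitro in place of hydrogen on an aromatic carbon. Among the measured compounds shown here, only one measured step exists for comparison, an at least 2.3-fold higher number from compound 1 to compound 2 (0.37 log units; beyond the scatter), where a small group was added to the phenyl attached to the shared core and the number rose; compound 2 sits at the limit of > 10000 nM in this assay, at which 1 of the 3 values shown sits, so the true size of that rise is unknown. The nitro group of compound 4 enters on a different ring, the one joined to the carbonyl, so that step is at best a rough guide. With nothing closer to lean on, a shift of little more than the scatter is expected, if anything toward a higher number. The step expected is a 1.4-fold higher number from compound 3 to compound 4 (0.14 log units; within the scatter). Compound 4 is therefore estimated at 1600 nM, with a likely range from 500 nM to 5000 nM.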

Compound 4, inhibition constant: > 10000 nM
Compound 4 gave a limit, no number; the forecaster's own chance of this, stated with the estimate: 5%; middle value at least 6.2-fold (0.79 log units) from the limit.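

In this assay, compound 4 reaches only > 10000 nM, a limit of the assay and not a number. Among the compounds shown here, the only earlier step came from a change on the phenyl attached to the shared core, and this result shows that the ring joined to the carbonyl also responds to a single substitution: nitro in place of hydrogen, on an aromatic carbon para to a large group, gives an at least 8.5-fold higher number from compound 3 to compound 4 (0.93 log units; beyond the scatter). The true size of this rise stays unknown, as it does for the earlier step, since the value of compound 4 is a limit: the limit of > 10000 nM in this assay, at which 2 of the 4 values shown sit.

The compounds shown leave open whether any group at this place raises the number, or whether the rise belongs to nitro in particular. A fluoro group, a methyl group or an amine at the same place on compound 3 would help separate those two readings, and nothing shown here tells which way such a compound would fall.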